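Methoxy removed from the pyrazole-bound phenyl: compound 3

A few compounds are considered here, and "the series" means these few. Any claim that something is new, unique, unknown or untested is made for them only; others in the source may bear on it.

Measured so far:
compound 1, `O=C1COc2ccc(-c3nn(-c4ccc(F)cc4)cc3-c3ccccc3)cc2N1`: 92.6%
compound 2, `COc1ccc(-n2cc(-c3ccccc3)c(-c3ccc4c(c3)NC(=O)CO4)n2)cc1`: 59.9%

In a functional assay on MV4-11 cells (Homo sapiens) for cytotoxicity, read by colorimetric assay and MTT assay, with a stated time of 3 days, tested at 20 uM (on this read-out higher numbers stand for a weaker effect at the one concentration tested and lower numbers for a stronger effect), compound 2 stands lowest of the two numbers, and its nearest neighbour is compound 1, which in this assay gives 92.6%. Among the measured compounds shown here, the only measured step, a number 32.7 percentage points lower from compound 1 to compound 2 (beyond the scatter), is large and beyond the scatter.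

Compound 3, `O=C1COc2ccc(-c3nn(-c4ccccc4)cc3-c3ccccc3)cc2N1`, differs from compound 2 by hydrogen in place of methoxy on an aromatic carbon. For the measured compounds named here, that step bears on the same methoxy whose arrival from fluoro marked the step from compound 1 to compound 2, so its removal is expected to move this assay back upward, but no measured step shows how hydrogen compares with fluoro at that place, and the size remains uncertain. The step is estimated as a number 20.1 percentage points higher from compound 2 to compound 3 (beyond the scatter). For compound 3 in this assay the expected value is 80%, within a range from 55% to 100%.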

Compound 3, a percentage reported as activity, at one concentration (the size of the read-out at that concentration, not a potency): 97.9%
Beside the measured number, compound 3's estimate is 17.9 percentage points below it; low and high end bracket the measured number.
By their numbers in this assay, from the lowest: compound 2; then compounds 1 and 3 (each within the scatter of the next).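

In this assay, the change from 4-methoxyphenyl to phenyl gives a number 38 percentage points higher from compound 2 to compound 3 (beyond the scatter), while hydrogen in place of fluoro gives a number 5.3 percentage points higher from compound 1 to compound 3 (within the scatter), so fluoro and hydrogen cannot be told apart at this place. The earlier pair could not show this: one step from fluoro to methoxy did not say how either group compared with hydrogen, and with hydrogen as the reference, the stronger effect at the one concentration tested goes with methoxy alone among these three groups. No measurement at hand explains the difference.

The compounds shown leave open whether a hydroxyl, an ethoxy, a methyl or a dimethylamino group at the same place would match methoxy. They also leave open whether methoxy elsewhere on this ring would give the same result.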